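Carboxy to ethoxycarbonyl on compound 3

This account rests on a few compounds, and the source may have more. Where it says the series, first, only, none or still open, it means among the compounds named here.

Of the compounds shown here, three sharing one core have been measured so far in a functional assay, with a stated time of 30 min (on this read-out lower numbers stand for an effect already at smaller amounts and higher numbers for an effect only at larger amounts of compound), on this series. Compound 1 `CCOC(=O)/C=C(/C(=O)OCC)[C@H]1c2c(cc(O)c(O)c2O)C(=O)O[C@@H]1C(=O)OC` gives 4400 nM on this read-out and compound 2 `CCOC(=O)/C=C(/C(=O)OCC)[C@H]1c2c(cc(O)c(O)c2O)C(=O)O[C@@H]1C(=O)O` gives 5400 nM on the same read-out. Compound 3 `CCOC(=O)C[C@@H](C(=O)O)[C@H]1c2c(cc(O)c(O)c2O)C(=O)O[C@@H]1C(=O)OCC` gives 15800 nM as the highest number of the three, beyond the scatter from both others. Compound 4 `CCOC(=O)C[C@@H](C(=O)OCC)[C@H]1c2c(cc(O)c(O)c2O)C(=O)O[C@@H]1C(=O)OCC` has not yet been measured. It differs from compound 3 by ethyl in place of hydrogen on an oxygen next to a carbonyl group in the form of ethyl in place of hydrogen on an oxygen next to a carbonyl group, which also reads as carboxy to ethoxycarbonyl. Among the compounds with values here, only one measured step bears on this change: a 1.2-fold higher number from compound 1 to compound 2 (0.09 log units; within the scatter) for hydrogen in place of methyl on an oxygen next to a carbonyl group. That step runs the opposite way, involves methyl and not ethyl, and comes from a pair whose side chain differs from that of compound 3, which makes it a loose guide. Even so, it gives no ground to expect a large shift in this assay from this kind of swap. The expected step is a 1.4-fold lower number from compound 3 to compound 4 (0.16 log units; within the scatter) and no move beyond the scatter is anticipated. For compound 4 the estimated value is 11000 nM with an expected range from 4500 nM to 28000 nM on this read-out.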

Compound 4, half-maximal effective concentration: 6800 nM
The estimate for compound 4 lay 1.6-fold (0.21 log units) above the measured number; the measured number falls inside the stated range.
By their numbers in this assay, from the lowest: compounds 1, 2 and 4 (each within the scatter of the next); then compound 3.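

At the carboxy group of compound 3, ethyl in place of hydrogen on an oxygen next to a carbonyl group gives in this assay a 2.3-fold lower number from compound 3 to compound 4 (0.37 log units; beyond the scatter) and so moves the read-out beyond the scatter, though only modestly. The earlier pair had shown a swap of this general kind only on a different side chain and at a different oxygen, where a 1.2-fold higher number from compound 1 to compound 2 (0.09 log units; within the scatter) stayed within the scatter, so the new step is the first sign that an alkyl group on such an oxygen can register on this read-out. It also shows that a free carboxylic acid at this position is not needed for an effect in this assay, since the ethoxycarbonyl form gives the lower number. Nothing given here explains why the step appears at this position and not in the earlier pair.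

The compounds shown leave open whether ethyl itself matters, since a methyl ester, a longer chain such as butyl, or a primary amide at this position would each test that. They also leave open whether the same swap would act in the same way on the side chain of compound 1, which carries a carbon-carbon double bond.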